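Sulfonyl substituent variation in the shared urea core

A few compounds are considered here, and "the series" means these few. Any claim that something is new, unique, unknown or untested is made for them only; others in the source may bear on it.

Measured so far in a functional assay on A2780 cells (Homo sapiens) for cytotoxicity, read by sulforhodamine B assay, with a stated time of 72 h; on this read-out higher numbers stand for weaker inhibition and lower numbers for stronger inhibition:
compound 1 `O=C(NCc1ccc(S(=O)(=O)c2ccccc2)cc1)N1CCc2ccncc2C1` — > 2000 nM (a limit of the assay)
compound 2 `CC(C)n1cc(S(=O)(=O)c2ccc(CNC(=O)N3Cc4ccncc4C3)cc2)cn1` — 11 nM
compound 3 `O=C(NCc1ccc(S(=O)(=O)C2CCCOC2)cc1)N1Cc2ccncc2C1` — 32 nM

Compound 1 gives only a limit in this assay, not a number, as shown by the limit of > 2000 nM in this assay, at which 1 of the 3 values shown sits. Among the two numbers, compound 3 stands highest; the one step measured in this assay, a 2.9-fold higher number from compound 2 to compound 3 (0.46 log units; beyond the scatter), puts compound 2 below it by a modest margin beyond the scatter.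

Compound 4 `CN1CCN(S(=O)(=O)c2ccc(CNC(=O)N3Cc4ccncc4C3)cc2)CC1` is not yet measured. It differs from compound 3 in one place: 4-methylpiperazin-1-yl in place of oxan-3-yl on a sulfonyl sulfur.

For the measured compounds named here, no measured step swaps one saturated ring for another on the sulfonyl sulfur, so nothing bears on this change directly. Going by the values given here, the only measured step, a 2.9-fold higher number from compound 2 to compound 3 (0.46 log units; beyond the scatter), concerns a different exchange and gives a weak guide; it shows that the group on the sulfonyl sulfur can shift the number by a modest amount. For compound 4 the expectation is therefore a small change in either direction, most likely within the scatter or slightly weaker, with a 1.9-fold higher number from compound 3 to compound 4 (0.27 log units; within the scatter) as the expected step. Compound 4 is estimated at 60 nM, in the range 15 nM to 300 nM.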

Compound 4, half-maximal inhibitory concentration: 71 nM
Compound 4: middle estimate off by 1.2-fold (0.07 log units), on the low side; low and high end bracket the measured number.
By their numbers in this assay, from the lowest: compound 2; then compound 3; then compound 4. At a limit, above all of these: compound 1.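

In this assay the exchange of oxan-3-yl for 4-methylpiperazin-1-yl on the sulfonyl sulfur gives a 2.2-fold higher number from compound 3 to compound 4 (0.35 log units; beyond the scatter) and so shows that these two six-membered non-aromatic rings are not interchangeable at this position. The step from 1-isopropyl-1H-pyrazol-4-yl to 4-methylpiperazin-1-yl, a 6.5-fold higher number from compound 2 to compound 4 (0.81 log units; beyond the scatter) in size, widens the range of numbers set by this sulfonyl substituent beyond what compound 2 and compound 3 had shown. Nothing shown gives a cause for either step.

On these data alone, whether the higher number with 4-methylpiperazin-1-yl goes with the second ring nitrogen or with its methyl group stays open. Piperazin-1-yl without the methyl group, piperidin-1-yl and morpholin-4-yl on the same sulfur would separate these features.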